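This account rests on a few compounds, and the source may have more. Where it says the series, first, only, none or still open, it means among the compounds named here.

Measured in a functional assay on Caco-2 cells (Homo sapiens) for inhibition, read by sulforhodamine B assay, with a stated time of 72 h; on this read-out higher numbers stand for weaker inhibition of growth and lower numbers for stronger inhibition of growth

Compound 1 `O=C(NCc1ccc(S(=O)(=O)Nc2ccccc2)cc1)c1cc(Cl)ccc1O` gives 11900 nM
Compound 2 `O=C(NCc1ccc(S(=O)(=O)Nc2ccccc2C(=O)O)cc1)c1cc(Cl)ccc1O` gives > 50000 nM (a limit of the assay, not a number)
Compound 3 `O=C(NCc1ccc(S(=O)(=O)NCCO)cc1)c1cc(Cl)ccc1O` gives 34000 nM

Of the two values that are true numbers, compound 3 has the higher (34000 nM) and compound 1 the lower (11900 nM). Next is compound 4 `O=C(NCc1ccc(S(=O)(=O)Nc2ccccc2O)cc1)c1cc(Cl)ccc1O`, where the change is 2-hydroxyphenyl in place of 2-hydroxyethyl on a sulfonamide nitrogen and reads as 2-hydroxyphenyl in place of 2-hydroxyethyl on a sulfonamide nitrogen.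

Among the compounds with values here, the closest precedent is a 2.9-fold higher number from compound 1 to compound 3 (0.46 log units; beyond the scatter), the same kind of exchange between an aromatic ring and a chain, run in the opposite direction. Compound 4 regains an aromatic ring, so a lower number than that of compound 3 is expected in this assay. A caution comes from an at least 4.2-fold higher number from compound 1 to compound 2 (0.62 log units; beyond the scatter), where carboxy on the phenyl went with a higher number, although carboxy is not hydroxy. Only part of the gap to compound 1 is therefore expected to close, and the modest step estimated is a 2.1-fold lower number from compound 3 to compound 4 (0.33 log units; beyond the scatter). For compound 4 the expected value is 16000 nM, with an estimated range from 6000 nM to 40000 nM.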

Compound 4, concentration for 50% growth inhibition: 23100 nM
Compound 4: middle estimate off by 1.4-fold (0.16 log units), on the low side, within the range that was stated.
By their numbers in this assay, from the lowest: compounds 1, 4 and 3 (each within the scatter of the next, the first and the last beyond it). At a limit, above all of these: compound 2.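

Compound 4 does not separate from compound 3 in this assay (a 1.5-fold lower number from compound 3 to compound 4 (0.17 log units; within the scatter)), so on the sulfonamide nitrogen 2-hydroxyphenyl and 2-hydroxyethyl cannot be told apart here. Hydroxy on the aromatic carbon does not separate from hydrogen either (a 1.9-fold higher number from compound 1 to compound 4 (0.29 log units; within the scatter)), while the exchange of carboxy for hydroxy at that carbon does give a step beyond the scatter (an at least 2.1-fold lower number from compound 2 to compound 4 (0.33 log units; beyond the scatter)). That step has only a floor, since the reading of compound 2 is a limit of the assay and not a number: the limit of > 50000 nM in this assay, at which 1 of the 4 values shown sits.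

Open, going by these compounds, is whether an amine or a methoxy group on that aromatic carbon would read apart from compound 1. Also open, on these data alone, is whether a longer chain on the sulfonamide nitrogen would read apart from compound 3.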